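Swapping the sulfonyl aryl group in a tetrahydropyridinyl indole series

The compounds below may be only part of what the source reports. "The series", "measured", "known", "first", "only" and "open" are said of these compounds alone.

compound 1 `O=S(=O)(c1ccccc1F)n1cc(C2=CCNCC2)c2ccccc21`: 2.7 nM
compound 2 `O=S(=O)(c1ccc(Cl)s1)n1cc(C2=CCNCC2)c2ccccc21`: 14.1 nM

In a functional assay on HeLa cells for inhibition of 5-hydroxytryptamine receptor 6 (Homo sapiens), read by cAMP accumulation (a higher number here means a weaker inhibitor, a lower number a stronger inhibitor), compound 1 gives 2.7 nM and compound 2 gives 14.1 nM. Compound 2 therefore stands highest of the two measured numbers, the step being a 5.2-fold higher number from compound 1 to compound 2 (0.72 log units; beyond the scatter). Compound 3 `O=S(=O)(c1nccc2sncc12)n1cc(C2=CCNCC2)c2ccccc21` is not yet measured; it differs from compound 2 by a group of 9 heavy atoms (6 carbon, 2 nitrogen, 1 sulfur; one five-membered aromatic ring with 2 hetero atoms, one six-membered aromatic ring with 1 hetero atom) in place of a group of 6 heavy atoms (4 carbon, 1 sulfur, 1 chlorine; one five-membered aromatic ring with 1 hetero atom), on a sulfonyl sulfur. Among the compounds with values here, the one measured step, a 5.2-fold higher number from compound 1 to compound 2 (0.72 log units; beyond the scatter), also exchanged the group on the sulfonyl sulfur and moved the number beyond the scatter, but it says nothing directly about the entering group. The number for compound 3 in this assay is expected to be 9 nM, within 3 nM to 30 nM, which is expected to mean a 1.6-fold lower number from compound 2 to compound 3 (0.19 log units; within the scatter).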

Compound 3, half-maximal inhibitory concentration: 169 nM
Compound 3: middle estimate off by 19-fold (1.27 log units), on the low side, and the stated range ends below it.
By their numbers in this assay, from the lowest: compound 1; then compound 2; then compound 3.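

In this assay, the group on the sulfonyl sulfur can cost far more than the exchange between the two single-ring groups showed: the fused two-ring group gives a 12-fold higher number from compound 2 to compound 3 (1.08 log units; beyond the scatter) and a 63-fold higher number from compound 1 to compound 3 (1.80 log units; beyond the scatter). Among these three compounds, the only one with two fused rings on the sulfur has the highest number. No measurement at hand explains this loss.

The second ring, the ring nitrogens and the absence of chlorine all change together in this step, and the compounds shown do not separate them. Also open, as far as these compounds go, is how a single-ring pyridin-3-yl or a fused naphthalen-1-yl group on the sulfonyl sulfur would compare.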